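Lengthening the Chain of a Chain-Bearing Pyrimidine Analogue

The source may hold more compounds than are shown below. What is called first, only, known or untested is meant among the compounds shown, and "the series" means these compounds.

Three compounds built on one shared core were tested in a functional assay on cells (Lymphocyte, Homo sapiens), read by a luciferase reporter and ATP content, with a stated time of 48 h, tested at 1 uM; a lower number here means a stronger effect, a higher number a weaker effect of the compound at the concentration tested. Compound 1 `CCCCCCCCCCCCCCCCc1nc(N2CCC2)nc(OC2CCC2)c1O` gives 100%, compound 2 `CCCCCCCCCCCCCCCCc1nc(OC2CCC2)nc(N2CCC2)c1O` gives 102%, and compound 3 `CCCCCCCCCCCCCCc1nc(OC2CCC2)nc(OC2CCC2)c1O` gives 99%. All three numbers lie within the usual scatter of one another, so none can be called stronger or weaker; compound 3 simply holds the smallest of the three, by margins that mean nothing.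

Compound 4 `CCCCCCCCCCCCCCCCc1nc(OC2CCC2)nc(OC2CCC2)c1O` differs from compound 3 in one place: ethyl in place of hydrogen on a saturated chain carbon, ten or more bonds along the chain from an aromatic carbon. Compounds 1 and 2 already carry this longer chain and show nothing beyond the scatter, so the step of a number 1 percentage points higher from compound 3 to compound 4 (within the scatter) is expected to be none beyond the scatter. Compound 4 is therefore estimated to give about 100% in this assay, between 90% and 110%.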

Compound 4, a percentage reported as activity, at one concentration (the size of the read-out at that concentration, not a potency): 98%
Compound 4: middle estimate off by 2 percentage points, on the high side; the range from low to high includes it.
By their numbers in this assay, from the lowest: compounds 4, 3, 1 and 2 (each within the scatter of the next).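

In this assay, ethyl in place of hydrogen on a saturated chain carbon, ten or more bonds along the chain from an aromatic carbon, gives a number 1 percentage points lower from compound 3 to compound 4 (within the scatter) and thus no effect that stands out from the scatter in a direct one-place comparison. Cyclobutyloxy in place of azetidin-1-yl on an aromatic carbon gives a number 4 percentage points lower from compound 2 to compound 4 (within the scatter) and a number 2 percentage points lower from compound 1 to compound 4 (within the scatter), so neither placement of that swap stands out either. No other data bear on these readings.

Going by these compounds, whether a much shorter chain, or an amine or carboxylic acid at the chain end, would shift the read-out remains open.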